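Aryl in place of cyclopropylmethyl on the shared core

The source may report more compounds than this note shows. Statements on the series, on what has been measured and on what is new or still open speak of the compounds shown alone.

Compound 1 `CC1C(=O)N(C)c2cnc(Nc3ccc(S(N)(=O)=O)cc3)nc2N1C`: 313 nM
Compound 2 `CN1C(=O)C(CC2CC2)N(C)c2nc(Nc3ccc(S(N)(=O)=O)cc3)ncc21`: 211 nM

In an assay on Sf9 cells for inhibition of serine/threonine-protein kinase 4 (Homo sapiens), read by luminescence and ADP-Glo, with a stated time of 1 h, in the presence of a further agent that is not named here (on this read-out lower numbers stand for stronger inhibition and higher numbers for weaker inhibition), compound 2 stands within the scatter of compound 1, as the step of a 1.5-fold lower number from compound 1 to compound 2 (0.17 log units; within the scatter) shows. Compound 3 `Cc1c(F)cccc1C1C(=O)N(C)c2cnc(Nc3ccc(S(N)(=O)=O)cc3)nc2N1C` is not yet measured. It differs from compound 2 by 3-fluoro-2-methylphenyl in place of cyclopropylmethyl on a saturated ring carbon. Going by the values given here, the only measured step, a 1.5-fold lower number from compound 1 to compound 2 (0.17 log units; within the scatter), exchanges hydrogen for cyclopropyl on a chain carbon and does not reach beyond the scatter; no measured step exchanges a chain for an aromatic ring on this ring carbon. Compound 3 is therefore expected to give 250 nM, between 70 nM and 900 nM, a step of a 1.2-fold higher number from compound 2 to compound 3 (0.07 log units; within the scatter) judged uncertain.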

Compound 3, half-maximal inhibitory concentration: 419 nM
Beside the measured number, compound 3's estimate is 1.7-fold (0.22 log units) below it, within the range that was stated.
By their numbers in this assay, from the lowest: compounds 2, 1 and 3 (each within the scatter of the next).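

In this assay, going by these compounds alone, this saturated ring carbon carries an aromatic ring for the first time: 3-fluoro-2-methylphenyl in place of cyclopropylmethyl gives (a 2.0-fold higher number from compound 2 to compound 3 (0.30 log units; within the scatter)), and in place of methyl gives (a 1.3-fold higher number from compound 1 to compound 3 (0.13 log units; within the scatter)). Methyl, cyclopropylmethyl and 3-fluoro-2-methylphenyl therefore all stand within the scatter of one another at this position, although the entering group is an aromatic ring rather than a chain. Nothing available explains this result. As far as these compounds go, whether an amine, a carboxylic acid or a longer chain on this ring carbon would reach beyond the scatter remains open. So does the outcome for plain phenyl, without the fluorine and the methyl.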